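The source may report more compounds than this note shows. Statements on the series, on what has been measured and on what is new or still open speak of the compounds shown alone.

Compound 3 `Clc1ccc2[nH]c(SCc3ccccc3SCc3ccccc3)nc2c1` is one of three close relatives sharing a core and differing only in one side group. In an assay on isolated protein for inhibition of Indoleamine 2,3-dioxygenase 1 (Homo sapiens), with a stated time of 60 min, tested at 10 uM (on this read-out lower numbers stand for less inhibition and higher numbers for more inhibition at the one concentration tested (going by the name of the read-out)), compound 3 gives 19%, level with compound 1 `Clc1ccc2[nH]c(SCc3ccccc3CCCc3ccccc3)nc2c1`, which gives 19%; together these are the two highest of the three numbers, while compound 2 `[O-][S+](Cc1ccccc1)c1ccccc1CSc1nc2cc(Cl)ccc2[nH]1` gives 11%. Every measured step among them, a number 8 percentage points lower from compound 1 to compound 2 (within the scatter), no change at the digits printed from compound 1 to compound 3 (within the scatter) and a number 8 percentage points higher from compound 2 to compound 3 (within the scatter), stays within the scatter.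

Compound 4 `Clc1ccc2[nH]c(SCc3ccccc3Cc3ccccc3)nc2c1` changes that same side group again: benzyl in place of benzylsulfanyl on an aromatic carbon. Since three swaps of the same group left this read-out unchanged within scatter, no step beyond the scatter is expected, a number 2 percentage points lower from compound 3 to compound 4 (within the scatter). Compound 4 is thus estimated at 17%, between 5% and 30%.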

Compound 4, a percentage reported as inhibition, at one concentration (the size of the read-out at that concentration, not a potency): 46%
Estimate against measurement, compound 4: 29 percentage points below, and the stated range ends below it.
By their numbers in this assay, from the lowest: compounds 2, 1 and 3 (each within the scatter of the next); then compound 4.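

The side group on this aromatic carbon does matter in this assay: benzyl stands clear of all three other side groups (a number 27 percentage points higher from compound 3 to compound 4 (beyond the scatter); a number 27 percentage points higher from compound 1 to compound 4 (beyond the scatter); a number 35 percentage points higher from compound 2 to compound 4 (beyond the scatter)). Compound 4 also carries the smallest of the four groups, but a single compound cannot show that size is what counts. Nothing available here explains the rise.

As far as these compounds go, it remains open how benzyloxy, or an amine or a carboxylic acid on the benzyl ring, would read here. A reading at one concentration also leaves the potency of compound 4 open.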